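The compounds below may be only part of what the source reports. "The series", "measured", "known", "first", "only" and "open" are said of these compounds alone.

Measured compounds: compound 1, `C#CCOc1ccc(-c2cc(-c3ccc(OCC#C)cc3)nc(-c3ccccc3)n2)cc1`, with 12300 nM in an assay on BTI-TN-5B1-4 cells for inhibition of Amine oxidase [flavin-containing] B (Homo sapiens), read by fluorescence and Amplex Red, using microsomes, with a stated time of 30 min; a lower number here means a stronger inhibitor, a higher number a weaker inhibitor; compound 2, `C#CCOc1ccc(-c2cc(-c3ccc(OCC#C)c(OCC)c3)nc(-c3ccccc3)n2)cc1`, with 29000 nM in this assay.

Compound 2 gives the higher of the two numbers shown; compound 1 stands nearest, and the step of a 2.4-fold higher number from compound 1 to compound 2 (0.37 log units; beyond the scatter) separates them. The change from compound 2 to compound 3, `C#CCOc1ccc(-c2cc(-c3ccc(OCC#C)c(OC)c3)nc(-c3ccccc3)n2)cc1`, is hydrogen in place of methyl on a saturated chain carbon bound to an oxygen on an aromatic ring. For the measured compounds named here, only one measured step bears on it: a 2.4-fold higher number from compound 1 to compound 2 (0.37 log units; beyond the scatter), where ethoxy replaced hydrogen on an aromatic carbon and the number rose beyond the scatter. Compound 3 carries methoxy at that carbon, which lies between the hydrogen of compound 1 and the ethoxy of compound 2 on the count of heavy atoms, so compound 3 is expected to fall between compound 1 and compound 2, with a step of a 1.5-fold lower number from compound 2 to compound 3 (0.16 log units; within the scatter) that may well stay within the scatter. Compound 3 is therefore estimated at 20000 nM, expected between 9000 nM and 45000 nM.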

Compound 3, half-maximal inhibitory concentration: 15700 nM
Beside the measured number, compound 3's estimate is 1.3-fold (0.11 log units) above it; low and high end bracket the measured number.
By their numbers in this assay, from the lowest: compounds 1, 3 and 2 (each within the scatter of the next, the first and the last beyond it).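

Compound 3 shows that at this aromatic carbon, methoxy cannot be told apart from either of the other two groups in this assay: shortening ethoxy to methoxy gives a 1.8-fold lower number from compound 2 to compound 3 (0.27 log units; within the scatter) and putting methoxy in place of hydrogen gives a 1.3-fold higher number from compound 1 to compound 3 (0.11 log units; within the scatter). Of the three groups, only hydrogen and ethoxy are separated, by a 2.4-fold higher number from compound 1 to compound 2 (0.37 log units; beyond the scatter), so the rise seen earlier needs the whole change from hydrogen to ethoxy and is not resolved at methoxy. Nothing available explains these numbers.

The compounds shown leave open whether a longer chain such as propoxy, or a hydroxyl or an amine on this carbon, would move the number clearly away from that of compound 1 in either direction. They also leave open whether methoxy or ethoxy elsewhere on the shared core would read the same.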